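The compounds below may be only part of what the source reports. "The series", "measured", "known", "first", "only" and "open" are said of these compounds alone.

Working notes on the series.

Compound 1 `Clc1ccc(-c2cc(-c3cccnc3)nc(-c3cccs3)c2)o1` gives 13000 nM in a functional assay on DU-145 cells (Homo sapiens) for cytotoxicity, in the presence of a further agent that is not named here; a lower number here means a stronger inhibitor, a higher number a weaker inhibitor. Compound 2 `Clc1ccc(-c2cc(-c3cccnc3)nc(-c3ccsc3)c2)o1` gives 21600 nM; the step of a 1.7-fold higher number from compound 1 to compound 2 (0.22 log units; within the scatter) goes with the change (thiophen-3-yl in place of thiophen-2-yl on an aromatic carbon), which occurs twice among the compounds here. Compound 3 `Cc1ccc(-c2cc(-c3ccc(Cl)o3)cc(-c3cccs3)n2)cc1` gives 19300 nM; its core differs from that of compound 1 by 4-methylphenyl in place of pyridin-3-yl on an aromatic carbon, with the step of a 1.5-fold higher number from compound 1 to compound 3 (0.17 log units; within the scatter). The three values lie within the scatter of one another, so no order is drawn from them.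

Compound 4 `Cc1ccc(-c2cc(-c3ccc(Cl)o3)cc(-c3ccsc3)n2)cc1` is not yet measured. It differs from compound 3 by thiophen-3-yl in place of thiophen-2-yl on an aromatic carbon, the same kind of change as that from compound 1 to compound 2, but around the place a 4-methylphenyl group stands where compound 1 carried a pyridin-3-yl group. Beside the step of a 1.7-fold higher number from compound 1 to compound 2 (0.22 log units; within the scatter), the step from compound 3 to compound 4 is expected to be about a 1.6-fold higher number from compound 3 to compound 4 (0.19 log units; within the scatter), because the single measured pair for this change, a 1.7-fold higher number from compound 1 to compound 2 (0.22 log units; within the scatter), stayed within the scatter. For compound 4 the estimate is 30000 nM, expected between 15000 nM and 60000 nM.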

Compound 4, half-maximal inhibitory concentration: 21200 nM
Estimate against measurement, compound 4: 1.4-fold (0.15 log units) above; the range from low to high includes it.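

In this assay, thiophen-3-yl in place of thiophen-2-yl gives a 1.1-fold higher number from compound 3 to compound 4 (0.04 log units; within the scatter), and this step reads the same as the one measured on the core of compound 1: the same change on two cores in this assay, a 1.7-fold higher number (0.22 log units; within the scatter) from compound 1 to compound 2 and a 1.1-fold higher number (0.04 log units; within the scatter) from compound 3 to compound 4, 1.5-fold (0.18 log units) apart, within the scatter of two such steps. With 4-methylphenyl in place of pyridin-3-yl, the step is a 1.0-fold lower number from compound 2 to compound 4 (0.01 log units; within the scatter), and this change also reads the same on both cores: the same change on two cores in this assay, a 1.5-fold higher number (0.17 log units; within the scatter) from compound 1 to compound 3 and a 1.0-fold lower number (0.01 log units; within the scatter) from compound 2 to compound 4, 1.5-fold (0.18 log units) apart, within the scatter of two such steps. Among these compounds, both changes therefore carry from one core to the other without a detectable difference, but no step lies beyond the scatter, so the four compounds cannot separate a shared effect of either change from no effect at all.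

Going by these compounds, all the groups compared here are aromatic rings, so it remains open whether an amine, a carboxylic acid or a longer alkyl chain in place of the 4-methylphenyl group would give a step beyond the scatter in this assay. On these data alone, the contribution of the 5-chlorofuran-2-yl group, present in all four compounds, also remains open.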